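This account rests on a few compounds, and the source may have more. Where it says the series, first, only, none or still open, it means among the compounds named here.

Values measured in a functional assay on RAW264.7 cells (Mus musculus) for inhibition; on this read-out lower numbers stand for stronger inhibition and higher numbers for weaker inhibition:

- Compound 1 `CC(C)=CCc1c(O)ccc(C(=O)[C@H]2[C@@H](c3cc(O)cc4oc(-c5ccc(O)cc5O)cc34)C=C(C)C[C@@H]2c2ccc(O)cc2O)c1O`: 12.8 ug/mL
- Compound 2 `O=C1CC(c2ccc(O)cc2O)Oc2cc(O)cc(O)c21`: 12.1 ug/mL

Compound 2, at 12.1 ug/mL, stands level with compound 1, at 12.8 ug/mL. The two numbers lie within the usual scatter of each other, even though the structures differ greatly in size.

Compound 3 `O=C1CC(c2ccc(O)cc2O)Oc2cc(O)ccc21` is compound 2 with one small edit: hydrogen in place of hydroxy on an aromatic carbon, ortho to a fused ring and meta to a hydroxy group (hydrogen in place of hydroxy on an aromatic carbon).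

Going by the values given here, no pair of measured compounds shows what this swap does in this assay, so any forecast here is loose. The expected result is a small shift towards weaker inhibition that stays within the scatter, a 1.2-fold higher number from compound 2 to compound 3 (0.09 log units; within the scatter). For compound 3 the estimated value is 15 ug/mL, with an expected range from 6 ug/mL to 40 ug/mL.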

Compound 3, half-maximal inhibitory concentration: 10.3 ug/mL
Estimate against measurement, compound 3: 1.5-fold (0.16 log units) above; measured number inside the range.
By their numbers in this assay, from the lowest: compounds 3, 2 and 1 (each within the scatter of the next).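

In this assay, hydrogen in place of hydroxy on this aromatic carbon, ortho to a fused ring and meta to a hydroxy group, gives a 1.2-fold lower number from compound 2 to compound 3 (0.07 log units; within the scatter) and so leaves the two compounds level. Going by these compounds alone, this is the first direct reading of this swap, since compound 1 and compound 2 differ in too many places to show it. Within the scatter of this assay, inhibition at the level of compound 2 does not depend on a hydroxy group at this position, and no measurement at hand explains the result.

Still open, as far as these compounds go, is whether a different group on this same carbon, such as methoxy, an amine or a carboxylic acid, would also leave the number level. Also open, from the compounds shown here alone, is whether the hydroxy groups elsewhere on the shared core can be exchanged for hydrogen just as freely.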